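Ethyl replaces 4-methoxycyclohexyl on an aromatic nitrogen

The source may hold more compounds than are shown below. What is called first, only, known or untested is meant among the compounds shown, and "the series" means these compounds.

Compound 1 `CNC(=O)Nc1ccc(-c2nc(N3CC4CCC(C3)O4)c3cnn(CCN(C)C)c3n2)cc1` and compound 2 `CNC(=O)Nc1ccc(-c2nc(N3CC4CCC(C3)O4)c3cnn([C@H]4CC[C@H](OC)CC4)c3n2)cc1` share one core and differ in the group on an aromatic nitrogen. In an in vitro ADME assay on microsomes (Mus musculus) for metabolic stability (a higher number here means that the compound lasts longer, a lower number that the compound disappears faster), compound 1 gives 0.0833 h. Compound 2 gives > 0.5 h, which is a limit of the assay and not a number.

Compound 3 `CCn1ncc2c(N3CC4CCC(C3)O4)nc(-c3ccc(NC(=O)NC)cc3)nc21` changes the same place once more: ethyl in place of 4-methoxycyclohexyl on an aromatic nitrogen. For the measured compounds named here, the only measured step that bears on this change is an at least 6.0-fold higher number from compound 1 to compound 2 (0.77 log units; beyond the scatter), which lies beyond the scatter and shows that the group at this place can matter in this assay. Ethyl is neither of the two groups compared in that step, so it offers only a loose guide. Compound 1, at 0.0833 h, serves as the low reference for the estimate, and a result for compound 3 close to that value is not expected. A moderate fall is expected instead, smaller than the measured step, and the expected change is an at least 1.6-fold lower number from compound 2 to compound 3 (0.22 log units; that floor lies within the scatter). For compound 3 the estimated half-life is 0.3 h, with an expected range from 0.12 h to 0.6 h.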

Compound 3, half-life: > 0.5 h
Compound 3: no number, only a limit; the forecaster's own chance of this, stated with the estimate: 30%; at least 1.6-fold (0.22 log units) between middle value and limit.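

In this assay compound 3 gives > 0.5 h, which is a limit of the assay and not a number. For the compounds shown here, the step of an at least 6.0-fold higher number from compound 1 to compound 3 (0.77 log units; beyond the scatter) comes with hydrogen in place of dimethylamino on a saturated chain carbon as the one change, so the rise seen earlier with 4-methoxycyclohexyl does not require that group's six-membered ring or its oxygen: ethyl has no ring and no oxygen, yet compound 3 also clears the value of compound 1 by a margin beyond the scatter. The step from compound 2 to compound 3 cannot be read, because both compounds stand at the same limit: the limit of > 0.5 h in this assay, at which 2 of the 3 values shown sit.

As far as these compounds go, it therefore remains open whether ethyl and 4-methoxycyclohexyl differ at all in this assay, and how long either compound lasts past the limit. The compounds shown also leave open whether a longer carbon chain, a hydroxyl group at the end of the ethyl chain, or an amine other than dimethylamino, such as a morpholine, would keep a compound at the limit or bring it back towards compound 1.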